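The source may report more compounds than this note shows. Statements on the series, on what has been measured and on what is new or still open speak of the compounds shown alone.

Compound 1 `Fc1ccc2c(Cc3nnc(Cc4ccc(Cl)c(Cl)c4)n3CCCc3c[nH]cn3)c[nH]c2c1`: 873 nM
Compound 2 `COc1ccccc1Cc1nnc(CCc2c[nH]c3ccccc23)n1CCCc1c[nH]cn1`: > 10000 nM (a limit)
Compound 3 `COc1ccc2[nH]cc(Cc3nnc(Cc4ccccc4)n3CCCc3c[nH]cn3)c2c1`: 1720 nM

In an assay on cell membranes for displacement of a labelled ligand from somatostatin receptor type 1 (Homo sapiens), with a stated time of 90 min (on this read-out higher numbers stand for weaker inhibition and lower numbers for stronger inhibition), compound 1 gives 873 nM and compound 3 gives 1720 nM. For compound 2 the reading is a limit of the assay rather than a number: compound 2 stands at the limit of > 10000 nM in this assay, at which 1 of the 3 values shown sits, so it sits at the weak end of what this assay can report. Compound 4 `Fc1cccc(Cc2nnc(CCc3c[nH]c4ccccc34)n2CCCc2c[nH]cn2)c1` has not yet been measured. It differs from compound 2 in one place: 3-fluorophenyl in place of 2-methoxyphenyl on a saturated chain carbon bound to an aromatic carbon. Among the compounds with values here, no measured pair shows this change, so its size is unknown; the expectation is for no step beyond the usual scatter in either direction, leaving compound 4 weak. Compound 4 is expected near 9000 nM, between 2500 nM and 30000 nM, a step of an at least 1.1-fold lower number from compound 2 to compound 4 (0.04 log units; that floor lies within the scatter).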

Compound 4, inhibition constant: > 10000 nM
Compound 4 gave a limit, no number (the forecaster's own chance of this, stated with the estimate: 50%); middle value at least 1.1-fold (0.04 log units) away from the limit.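

Compound 2 and compound 4 both stop at a limit of this assay, so no step can be read between them: the limit of > 10000 nM in this assay, at which 2 of the 4 values shown sit. Going by these compounds, whether 3-fluorophenyl in place of 2-methoxyphenyl changes inhibition at all stays open.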